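The compounds below may be only part of what the source reports. "The series", "measured", "known", "first", "only" and "open" are said of these compounds alone.

The account opens with two compounds already measured in a functional assay on ECa-109 cells for inhibition, with ECa-109 cell line (Homo sapiens) as the target, read by sulforhodamine B assay (on this read-out lower numbers stand for stronger inhibition and higher numbers for weaker inhibition), and a third awaiting its result. Compound 1 `CCc1ccc(NC2=CC(=O)c3c(nc4n3[C@H]3OC[C@@H](O)[C@H]3OC4)C2=O)cc1` carries an ethyl group on an aromatic carbon. In this assay compound 1 reaches only a limit, > 4000 nM, and no number. Compound 2 `O=C1C(Nc2ccc(C(F)(F)F)cc2)=CC(=O)c2c1nc1n2[C@H]2OC[C@@H](O)[C@H]2OC1` carries trifluoromethyl in place of ethyl on an aromatic carbon, and in this assay compound 2 gives 2250 nM. Within the data shown here, that is the only number on record; the other value sits at the limit of > 4000 nM in this assay, at which 1 of the 2 values shown sits. Among the measured compounds shown here, the one measured step is an at least 1.7-fold lower number from compound 1 to compound 2 (0.24 log units; that floor lies within the scatter), and its floor lies within the scatter.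

Compound 3 `CCCc1ccc(NC2=CC(=O)c3c(nc4n3[C@H]3OC[C@@H](O)[C@H]3OC4)C2=O)cc1` differs from compound 2 by propyl in place of trifluoromethyl on an aromatic carbon. This change runs the other way from the measured step, bringing back an alkyl chain in place of trifluoromethyl, one carbon longer than the ethyl of compound 1. The number is therefore expected to rise rather than fall, with a 2.2-fold higher number from compound 2 to compound 3 (0.35 log units; beyond the scatter) expected for the step. Compound 3 is estimated at 5000 nM, within a range from 2000 nM to 12000 nM, and may well return only a limit.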

Compound 3, half-maximal inhibitory concentration: > 4000 nM
Compound 3 ended at the assay's limit; the forecaster's own chance of this, stated with the estimate: 55%; the middle value lies beyond the limit too.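

Compound 3 reaches only a limit in this assay and gives no number, so two alkyl-bearing compounds now stand without a number at this position: the limit of > 4000 nM in this assay, at which 2 of the 3 values shown sit. Exchanging trifluoromethyl for propyl on this aromatic carbon, para to a large group, gives an at least 1.7-fold higher number from compound 2 to compound 3 (0.24 log units; that floor lies within the scatter); the result shows that a second alkyl chain, and not ethyl alone, yields no number here, but the step cannot establish a real loss of inhibition. The step from ethyl to propyl cannot be read, as both of its ends are limits, so it tells nothing about the effect of chain length at this position.

On these data alone, the true values of compound 1 and compound 3 remain unknown, and so does whether either lies close to compound 2 or far from it. The compounds shown also leave open how a nitrile, a methoxy group, a chlorine atom or an amine at this place on the ring would read, and whether trifluoromethyl stands apart from such groups or merely from these two alkyl chains.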